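Aryl swap on compound 1: working notes

The compounds below may be only part of what the source reports. "The series", "measured", "known", "first", "only" and "open" are said of these compounds alone.

- compound 1 `COc1ccc(NC(=S)NCCNS(=O)(=O)c2sccc2-c2ccc(C)cc2Oc2ccc(O)c(O)c2)cc1` gives 8300 nM
- compound 2 `O=[N+]([O-])c1ccc(NC(=S)NCCNS(=O)(=O)c2ccc(-c3ccccc3OCc3cccc(O)c3)s2)cc1` gives 10100 nM
- compound 3 `COc1ccc(Oc2ccccc2-c2ccsc2S(=O)(=O)N2CCN(C(=O)Nc3ccc(F)cc3)CC2)cc1OC` gives 14900 nM

In a functional assay on RS4-11 cells (Homo sapiens) for inhibition, read by CCK-8 assay, with a stated time of 48 h (a higher number here means a weaker inhibitor, a lower number a stronger inhibitor), compound 1 stands at 8300 nM and lies within the usual scatter of both compound 2 and compound 3, so the three values do not separate from one another.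

The next step leads to compound 4 `Cc1ccc(-c2ccsc2S(=O)(=O)NCCNC(=S)Nc2cccc([N+](=O)[O-])c2)c(Oc2ccc(O)c(O)c2)c1` and puts 3-nitrophenyl in place of 4-methoxyphenyl on an amide-type nitrogen while the rest of compound 1 stays as it is. Within the data shown here, no two measured compounds differ in one place only, so the series holds no direct measure of this change.

The only hint is indirect. Compound 2 also carries a nitrophenyl group on an amide-type nitrogen and reads 10100 nM in this assay without separating from compound 1, although it differs from compound 1 elsewhere as well.

On that basis the expected result is a 1.1-fold lower number from compound 1 to compound 4 (0.04 log units; within the scatter) and this estimated step stays within the scatter, with no firm direction in this assay for now. Compound 4 is estimated at 7500 nM (expected range 2800 nM to 18000 nM).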

Compound 4, half-maximal inhibitory concentration: 6100 nM
Compound 4: middle estimate off by 1.2-fold (0.09 log units), on the high side; low and high end bracket the measured number.
By their numbers in this assay, from the lowest: compounds 4, 1, 2 and 3 (each within the scatter of the next, the first and the last beyond it).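

In this assay, the exchange on the amide-type nitrogen whose other neighbour is the thiocarbonyl carbon now has a direct reading: 3-nitrophenyl in place of 4-methoxyphenyl gives a 1.4-fold lower number from compound 1 to compound 4 (0.13 log units; within the scatter) with the rest of the molecule held constant. Among these compounds, earlier comparisons at this position were confounded by differences elsewhere, whereas this single-place step shows that the two aryl groups do not separate here. Because 4-methoxyphenyl and 3-nitrophenyl differ both in the group carried and in where it stands on the ring, the step cannot be assigned to either difference alone, and no measured property bears on the result.

Still open, going by these compounds, is whether 3-methoxyphenyl, unsubstituted phenyl or a ring carrying a primary amine or a carboxylic acid would separate from compound 1 at this nitrogen. Also open, on these data alone, is whether any single-place change elsewhere, such as a longer chain in place of the linker of compound 1, would give a step beyond the scatter in this assay.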